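A few compounds are considered here, and "the series" means these few. Any claim that something is new, unique, unknown or untested is made for them only; others in the source may bear on it.

Within the data shown here, in a functional assay on MV4-11 cells (Homo sapiens) for antiproliferative activity, read by CCK-8 assay, with a stated time of 72 h (a lower number here means a stronger inhibitor, a higher number a weaker inhibitor), compound 1 (`Cn1cc(-c2cccc(Cl)c2)c2cc(C(=O)NCc3ccc(C(=O)Nc4ccccc4N)cc3)[nH]c2c1=O`) gives 190 nM and compound 2 (`COc1ccccc1-c1cn(C)c(=O)c2[nH]c(C(=O)NCc3ccc(C(=O)Nc4ccccc4N)cc3)cc12`) gives 200 nM, so compound 2 stands level with compound 1, the only other measured compound, within the scatter. Compound 3 (`COc1ccc(-c2cn(C)c(=O)c3[nH]c(C(=O)NCc4ccc(C(=O)Nc5ccccc5N)cc4)cc23)cc1`) is the next to consider, with the change 4-methoxyphenyl in place of 2-methoxyphenyl on an aromatic carbon. Among the measured compounds shown here, only one measured step bears on this place, a 1.1-fold higher number from compound 1 to compound 2 (0.02 log units; within the scatter), where 2-methoxyphenyl replaced 3-chlorophenyl. For the measured compounds named here, that step stays within the scatter, but it is a single step, and no measured compound carries 4-methoxyphenyl. No shift beyond the scatter is therefore expected in this assay, and neither direction is favoured. The expected step is no change at the digits printed from compound 2 to compound 3 (within the scatter). For compound 3 the estimated value is 200 nM, with an expected range of 90 nM to 450 nM.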

Compound 3, half-maximal inhibitory concentration: 320 nM
Compound 3: the middle estimate sits 1.6-fold (0.20 log units) below what was measured; measured number inside the range.
By their numbers in this assay, from the lowest: compounds 1, 2 and 3 (each within the scatter of the next).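

In this assay, the place on the shared core now has a comparison of two groups with the same atoms: 4-methoxyphenyl in place of 2-methoxyphenyl gives a 1.6-fold higher number from compound 2 to compound 3 (0.20 log units; within the scatter), so the two methoxyphenyl isomers are not told apart at this place. 4-methoxyphenyl in place of 3-chlorophenyl gives a 1.7-fold higher number from compound 1 to compound 3 (0.23 log units; within the scatter), so all three substituted phenyl groups shown here lie within the scatter of one another in this assay. No measurement at hand accounts for these readings.

On these data alone, whether a group without a phenyl ring at this place, such as an amine, a carboxylic acid or a short alkyl chain, would move the number beyond the scatter remains open. As far as these compounds go, it is also open whether 3-methoxyphenyl or an unsubstituted phenyl would read with these three.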